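The source may report more compounds than this note shows. Statements on the series, on what has been measured and on what is new or still open speak of the compounds shown alone.

In a functional assay on MCF7 cells (Homo sapiens) for cytotoxicity, read by MTT assay, with a stated time of 72 h (on this read-out higher numbers stand for weaker inhibition and lower numbers for stronger inhibition), compound 1 `CC(C)[S+]([O-])CCCCN=C=S` gives 8820 nM, the highest of the three measured numbers. In this assay compound 2 `[O-][S+](CCCCN=C=S)Cc1ccccc1` gives 3300 nM, and compound 3 `[O-][S+](CCCCCN=C=S)Cc1ccccc1` gives 3830 nM. The difference between the cores of compound 1 and compound 2 is not broken down here. Compound 3 differs from compound 2 by a group of 4 heavy atoms (2 carbon, 1 nitrogen, 1 sulfur; no ring) in place of a group of 3 heavy atoms (1 carbon, 1 nitrogen, 1 sulfur; no ring), on a saturated chain carbon, four bonds along the chain from a sulfur, and that change gave a 1.2-fold higher number from compound 2 to compound 3 (0.06 log units; within the scatter). Compound 4 `CC(C)[S+]([O-])CCCCCN=C=S` has not yet been measured in this assay; it differs from compound 1 by a group of 4 heavy atoms (2 carbon, 1 nitrogen, 1 sulfur; no ring) in place of a group of 3 heavy atoms (1 carbon, 1 nitrogen, 1 sulfur; no ring), on a saturated chain carbon, four bonds along the chain from a sulfur, the same change as that from compound 2 to compound 3. Because the measured step of a 1.2-fold higher number from compound 2 to compound 3 (0.06 log units; within the scatter) lies within the scatter, the expected step of a 1.1-fold higher number from compound 1 to compound 4 (0.03 log units; within the scatter) is likewise estimated to be small. On that basis compound 4 is expected to give 9500 nM, estimated to lie between 4500 nM and 20000 nM.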

Compound 4, half-maximal inhibitory concentration: 6780 nM
Compound 4: middle estimate off by 1.4-fold (0.15 log units), on the high side, and the stated range covers the measured number.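

In this assay the new step is a 1.3-fold lower number from compound 1 to compound 4 (0.11 log units; within the scatter), and set beside the earlier step, the same change reads alike on the two cores: the same change on two cores in this assay, a 1.2-fold higher number (0.06 log units; within the scatter) from compound 2 to compound 3 and a 1.3-fold lower number (0.11 log units; within the scatter) from compound 1 to compound 4, 1.5-fold (0.18 log units) apart, within the scatter of two such steps.

Across these two cores, then, the change carries over as a step too small to tell from the scatter, and the opposite directions of the two numbers mean nothing. This does not show that the change is without effect on other cores, and, with no step beyond the scatter, it does not test whether a larger effect would carry over.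

Going by these compounds, what a longer chain would do on either core remains open. So does the effect of a methyl group on the sulfur.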